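This account rests on a few compounds, and the source may have more. Where it says the series, first, only, none or still open, it means among the compounds named here.

The shared core of compound 3, `COc1cc2nc(N3CCC(N4CCCC(CO)C4)CC3)nc(Nc3ccc(Cl)cc3)c2cc1OC`, carries a hydroxymethyl group on one side and a 4-chlorophenyl group on a nitrogen on an aromatic ring on the other. In an in vitro functional assay on B300-19 cells for antagonist activity at C-C chemokine receptor type 4 (Homo sapiens) (on this read-out lower numbers stand for stronger inhibition and higher numbers for weaker inhibition), compound 3 gives 23 nM, the lowest of the two numbers obtained in this series. Within the data shown here, its nearest neighbour is compound 1, `COc1cc2nc(N3CCC(N4CCCC(CO)C4)CC3)nc(NCc3ccc(Cl)cc3)c2cc1OC`, which in this assay gives 450 nM; the step of a 20-fold lower number from compound 1 to compound 3 (1.29 log units; beyond the scatter) is the only measured step in the set and exchanges the group on the aromatic amine. A third member, compound 2, `COc1cc2nc(N3CCC(N4CCCC(CO)C4)CC3)nc(NC3CCS(=O)(=O)CC3)c2cc1OC`, carries a saturated sulfone ring on that nitrogen, and in this assay compound 2 gives "not determined" (no result reported), so no result is available for it.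

Compound 4, `COCC1CCCN(C2CCN(c3nc(Nc4ccc(Cl)cc4)c4cc(OC)c(OC)cc4n3)CC2)C1`, differs from compound 3 by methyl in place of hydrogen on an oxygen on a saturated carbon. Among the measured compounds shown here, no measured step in the set touches this position: the only step, from compound 1 to compound 3, concerns the other end of the molecule, so it offers no direct guide. With the capped hydroxy group as the sole alteration, compound 4 is expected to behave much like compound 3, with a step of a 1.3-fold higher number from compound 3 to compound 4 (0.12 log units; within the scatter) that stays within the scatter. The estimate for compound 4 in this assay is therefore 30 nM, in a range from 10 nM to 90 nM.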

Compound 4, half-maximal inhibitory concentration: 64 nM
Compound 4: the middle estimate sits 2.1-fold (0.33 log units) below what was measured; measured number inside the range.
By their numbers in this assay, from the lowest: compound 3; then compound 4; then compound 1.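

Methyl in place of hydrogen on the oxygen of the hydroxymethyl group gives a 2.8-fold higher number from compound 3 to compound 4 (0.44 log units; beyond the scatter) in this assay and so shows that this end of the molecule, which no earlier step touched, does register on this read-out. The hydroxy hydrogen is not indispensable, as compound 4 still gives 64 nM as a methoxymethyl compound, and the step is smaller than a 20-fold lower number from compound 1 to compound 3 (1.29 log units; beyond the scatter) at the group on the aromatic amine. The material shown offers no evidence that would account for this shift.

As far as these compounds go, it remains open how the position would respond to groups other than methoxymethyl, such as a longer ethoxymethyl chain, an aminomethyl group or a carboxylic acid, and so whether the rise in the number continues with larger groups on the oxygen or depends on the oxygen being there at all. Also open, from the compounds shown here alone, is whether the same capping would produce a step of similar size with 4-chlorobenzyl on the aromatic amine, as in compound 1, rather than with 4-chlorophenyl.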